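Removing a methyl from an aromatic oxygen: a repeated step

The compounds below may be only part of what the source reports. "The series", "measured", "known", "first", "only" and "open" are said of these compounds alone.

Measured compounds:
- compound 1, `O=C(Nc1cccc(-n2cc(-c3ccncc3)c(-c3ccc(Cl)c(O)c3)n2)c1)Nc1cccc(C(F)(F)F)c1`: 20100 nM
- compound 2, `COc1cc(-c2nn(-c3cccc(NC(=O)Nc4cccc(C(F)(F)F)c4)c3)cc2-c2ccncc2)ccc1Cl`: 2410 nM
- compound 3, `COc1cc(-c2nn(-c3cccc(NC(=O)Nc4ccc(Cl)c(C(F)(F)F)c4)c3)cc2-c2ccncc2)ccc1Cl`: 2350 nM

These three compounds were tested in a functional assay on Malme-3M cells (Homo sapiens) for inhibition, read by sulforhodamine B assay, with a stated time of 48 h; on this read-out lower numbers stand for stronger inhibition of growth and higher numbers for weaker inhibition of growth. Compound 2 and compound 3 differ only by chloro in place of hydrogen on an aromatic carbon, and the step of a 1.0-fold lower number from compound 2 to compound 3 (0.01 log units; within the scatter) shows that this change leaves the result essentially unchanged. Compound 1 is made from compound 2 by hydrogen in place of methyl on an oxygen on an aromatic ring, and the step of an 8.3-fold higher number from compound 2 to compound 1 (0.92 log units; beyond the scatter) is a clear weakening.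

Compound 4, `O=C(Nc1cccc(-n2cc(-c3ccncc3)c(-c3ccc(Cl)c(O)c3)n2)c1)Nc1ccc(Cl)c(C(F)(F)F)c1`, has not been measured. It is made from compound 3 by hydrogen in place of methyl on an oxygen on an aromatic ring, the same change that turns compound 2 into compound 1, at the same place. Because the step of an 8.3-fold higher number from compound 2 to compound 1 (0.92 log units; beyond the scatter) was beyond the scatter, a step of similar size is expected here; compound 2 and compound 3 also give closely matching numbers, so compound 4 is expected to sit near compound 1. The step of an 8.3-fold higher number from compound 3 to compound 4 (0.92 log units; beyond the scatter) is therefore estimated for compound 4. For compound 4 the expected value in this assay is 19500 nM, with a range of 8000 nM to 45000 nM.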

Compound 4, concentration for total growth inhibition: 1650 nM
Estimate against measurement, compound 4: 12-fold (1.07 log units) above; the whole stated range lies above it.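

In this assay, the change from methoxy to hydroxy gives a 1.4-fold lower number from compound 3 to compound 4 (0.15 log units; within the scatter), so its effect does not carry over unchanged from one core to the other: the same change on two cores in this assay, an 8.3-fold higher number (0.92 log units; beyond the scatter) from compound 2 to compound 1 and a 1.4-fold lower number (0.15 log units; within the scatter) from compound 3 to compound 4, 12-fold (1.07 log units) apart, beyond the scatter of two such steps. The added chloro on the trifluoromethyl-bearing ring also depends on its surroundings, giving a 12-fold lower number from compound 1 to compound 4 (1.09 log units; beyond the scatter), so a step measured with hydroxy present does not match the one measured with methoxy present: the same change on two cores in this assay, a 1.0-fold lower number (0.01 log units; within the scatter) from compound 2 to compound 3 and a 12-fold lower number (1.09 log units; beyond the scatter) from compound 1 to compound 4, 12-fold (1.07 log units) apart, beyond the scatter of two such steps. These four compounds show that the two changes do not simply add up, so a step from one core cannot be copied safely to another, but they do not show why this happens or whether it holds beyond these compounds.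

Going by these compounds, it remains open how other groups at the same place on the ring, such as an ethoxy or an amine, would fit this picture. On these data alone, it is also open whether a fluoro in place of the added chloro would show the same dependence on the neighbouring hydroxy or methoxy.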